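A few compounds are considered here, and "the series" means these few. Any claim that something is new, unique, unknown or untested is made for them only; others in the source may bear on it.

Compound 1 `COc1ccc(CN(Cc2ccc(C(C)(C)C)cc2)Cc2cc3cc(C)ccc3[nH]c2=O)cc1`: in a toxicity assay on MDCK cells (Canis lupus familiaris) for cytotoxicity, read by crystal violet staining, with a stated time of 48 h (on this read-out lower numbers stand for higher toxicity in this test and higher numbers for lower toxicity in this test), compound 1 gives > 10000 nM, which is a limit of the assay.
Compound 2 `Cc1ccc2[nH]c(=O)c(CN(Cc3ccc(OC(C)C)cc3)Cc3ccc(C(C)(C)C)cc3)cc2c1`: in this assay compound 2 gives > 5000 nM, again a limit.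
Compound 3 `Cc1ccc2[nH]c(=O)c(CN(Cc3ccc(C(C)(C)C)cc3)[C@H](C)c3ccc(F)cc3)cc2c1`: in this assay compound 3 gives > 5000 nM, also a limit.

Compound 3 thus stands at a limit, as do the two further values shown (the limit of > 10000 nM in this assay, at which 1 of the 3 values shown sits; (the limit of > 5000 nM in this assay, at which 2 of the 3 values shown sit)). Compound 4 `Cc1ccc2[nH]c(=O)c(CN(Cc3ccc(C(C)(C)C)cc3)Cc3ccc(N(C)C)c(Cl)c3)cc2c1` differs from it by 3-chloro-4-(dimethylamino)benzyl in place of 1-(4-fluorophenyl)ethyl on an amine nitrogen. The measured steps that bear on this position, a step that the two limits leave unreadable from compound 1 to compound 3 and a step that the two limits leave unreadable from compound 2 to compound 3, are both unreadable. Every value in this assay sits at a limit. No readable step in this assay is therefore expected. Compound 4 is estimated at 8000 nM, within 3000 nM to 20000 nM, most likely reported as a limit again. The expected step is a step that the limit leaves unreadable from compound 3 to compound 4.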

Compound 4, half-maximal cytotoxic concentration: > 10000 nM
Compound 4 was reported as a limit (the forecaster's own chance of this, stated with the estimate: 70%); at least 1.2-fold (0.09 log units) between middle value and limit.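

In this assay compound 4 gives > 10000 nM, which is a limit. Its steps from compound 1, compound 2 and compound 3, which also stand at limits, cannot be read. The compounds shown leave open at what concentration any of them becomes toxic to these cells.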